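The source may report more compounds than this note shows. Statements on the series, on what has been measured and on what is new or still open speak of the compounds shown alone.

Compound 2 `CN(Cc1ccc(C#N)cc1)Cc1ccc(COc2ccc3ccc(=O)oc3c2)cc1` has the stronger of the two numbers recorded so far. Within the data shown here, in an assay for inhibition of Amine oxidase [flavin-containing] B (Rattus norvegicus), read by spectrophotometry (a lower number here means a stronger inhibitor, a higher number a weaker inhibitor), compound 2 gives 270 nM, whereas compound 1 `Cc1cc2ccc(OCc3ccc(CN(C)Cc4cccc(Cl)c4)cc3)cc2oc1=O`, which carries a chlorine on its benzyl group and a methyl on its shared core, gives 4500 nM; these two values differ in more than one place, so they set no single step. Compound 3 `Cc1cc2ccc(OCc3ccc(CN(C)Cc4ccc(C#N)cc4)cc3)cc2oc1=O` keeps the nitrile-bearing benzyl group of compound 2 and changes only the core: methyl in place of hydrogen on an aromatic carbon. Among the measured compounds shown here, no measured pair isolates this change, so the direction rests on thin ground. The weaker number of compound 1, 4500 nM, is the only hint that a methylated core may cost potency, and that hint is confounded by its different benzyl group. A modest loss is therefore expected, with the step of a 2.2-fold higher number from compound 2 to compound 3 (0.35 log units; beyond the scatter) treated as uncertain in sign. The estimate for compound 3 in this assay is 600 nM, within a range of 150 nM to 2500 nM.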

Compound 3, half-maximal inhibitory concentration: 1700 nM
For compound 3 the middle estimate is 2.8-fold (0.45 log units) below the measured one; measured number inside the range.
By their numbers in this assay, from the lowest: compound 2; then compound 3; then compound 1.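

In this assay the methyl in place of hydrogen on an aromatic carbon of the shared core can now be read on its own as a 6.3-fold higher number from compound 2 to compound 3 (0.80 log units; beyond the scatter) and so this position, two atoms from the ring oxygen, does not take the added methyl without a loss of potency. With that methyl present, 4-cyanophenyl in place of 3-chlorophenyl on a saturated chain carbon bound to an amine nitrogen gives a 2.6-fold lower number from compound 1 to compound 3 (0.42 log units; beyond the scatter) and so the benzyl group still affects potency on the methylated core. Nothing measured here explains either step.

On these data alone, it remains open whether the loss is particular to methyl, or whether an ethyl group or a fluorine atom on the same carbon would behave alike. As far as these compounds go, it is also open whether the change between these two benzyl groups would be of similar size on the core without the methyl.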